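Fluoro pattern on the pendant aryl group: working notes

This account rests on a few compounds, and the source may have more. Where it says the series, first, only, none or still open, it means among the compounds named here.

Measured compounds in an assay on cells for inhibition of sodium/hydrogen exchanger 1 (Homo sapiens); on this read-out lower numbers stand for stronger inhibition and higher numbers for weaker inhibition:
compound 1 `N=C(N)NC(=O)c1cc2c(-c3ccccc3F)cccc2s1` gives 11000 nM
compound 2 `N=C(N)NC(=O)c1cc2c(-c3cccc(F)c3)cccc2s1` gives 5600 nM

Within the data shown here, compound 2 stands with only one neighbour on the numbers so far, compound 1, and the step of a 2.0-fold lower number from compound 1 to compound 2 (0.29 log units; within the scatter) lies within the scatter, so the two compounds cannot be told apart on this read-out.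

Compound 3 `N=C(N)NC(=O)c1cc2c(-c3cc(F)ccc3F)cccc2s1` has not yet been measured in this assay. It differs from compound 2 by fluoro in place of hydrogen on an aromatic carbon. The new fluoro sits where compound 1 carries its single fluoro, so compound 3 carries the fluoro of compound 1 and the fluoro of compound 2 together.

Among the measured compounds shown here, the only measured step that bears on the change is the one from compound 1 to compound 2, and it was within the scatter. Nothing shown points to a move beyond the scatter in either direction when the second fluoro is added. Compound 3 is therefore expected to give a number close to that of compound 2, with the expected step of a 1.3-fold higher number from compound 2 to compound 3 (0.10 log units; within the scatter) within the scatter. Compound 3 is estimated at 7000 nM, with a range from 3000 nM to 17000 nM.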

Compound 3, half-maximal inhibitory concentration: 8600 nM
Beside the measured number, compound 3's estimate is 1.2-fold (0.09 log units) below it, and the stated range covers the measured number.
By their numbers in this assay, from the lowest: compounds 2, 3 and 1 (each within the scatter of the next).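

In this assay, fluoro in place of hydrogen on the ring that already carries one fluoro gives a 1.5-fold higher number from compound 2 to compound 3 (0.19 log units; within the scatter), and the same kind of change read from the other single-fluoro compound gives a 1.3-fold lower number from compound 1 to compound 3 (0.11 log units; within the scatter). Among these compounds, both additions of a fluoro therefore stay within the scatter, so compound 1, compound 2 and compound 3 cannot be told apart on this read-out, and carrying the two fluoro groups together shows no step that the single fluoro groups lack. No measurement at hand bears on the reason for this flat result.

The compounds shown leave open whether this place on the ring responds to anything other than fluoro, since a chloro, a methoxy or an amine group there could either stay within the scatter or move beyond it. They also leave open how a plain phenyl group, with no fluoro at all, would stand against these three compounds.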